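This account rests on a few compounds, and the source may have more. Where it says the series, first, only, none or still open, it means among the compounds named here.

The series shares one core; compound 1 `O=C1/C(=C/c2ccc(Cl)cc2)c2ccccc2N1c1c(Cl)cccc1Cl` carries a 4-chlorophenyl on the exocyclic double bond, compound 2 `COc1ccc(/C=C2/C(=O)N(c3c(Cl)cccc3Cl)c3ccccc32)cc1` a 4-methoxyphenyl and compound 3 `O=C1/C(=C/c2ccccc2[N+](=O)[O-])c2ccccc2N1c1c(Cl)cccc1Cl` a 2-nitrophenyl. In a functional assay on SW-620 cells (Homo sapiens) for cytotoxicity, read by MTT assay, with a stated time of 3 days (a higher number here means that more compound is needed for the effect, a lower number that less compound is needed), compound 1 gives 100 ug/mL. In this assay compound 3 gives 90 ug/mL, the lowest of the two numbers shown, though a 1.1-fold lower number from compound 1 to compound 3 (0.05 log units; within the scatter). For compound 2 this assay reports only a limit, > 100 ug/mL, which is the limit of > 100 ug/mL in this assay, at which 1 of the 3 values shown sits. Compound 4 `O=C1/C(=C/c2ccc(F)cc2)c2ccccc2N1c1c(Cl)cccc1Cl` is the next member: 4-fluorophenyl in place of 2-nitrophenyl on a double-bonded chain carbon bound to a double-bonded ring carbon. Among the compounds with values here, the steps that bear on this change are small; a 1.1-fold lower number from compound 1 to compound 3 (0.05 log units; within the scatter), and an at least 1.1-fold lower number from compound 2 to compound 3 (0.04 log units; that floor lies within the scatter) against a limit, while a number no lower from compound 1 to compound 2 (the limit leaves the size open) is open in size. A change of one para substituent on this phenyl has so far moved nothing beyond the scatter, so for compound 4 the expected step is a 1.1-fold higher number from compound 3 to compound 4 (0.05 log units; within the scatter), with a real chance that this assay again returns only a limit. The estimate for compound 4 in this assay is 100 ug/mL, ranging from 50 ug/mL to 200 ug/mL.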

Compound 4, concentration for half-maximal effect: 5 ug/mL
For compound 4 the middle estimate is 20-fold (1.30 log units) above the measured one, and the stated range ends above it.
By their numbers in this assay, from the lowest: compound 4; then compounds 3 and 1 (each within the scatter of the next).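

Within the data shown here, the aryl group on a double-bonded chain carbon bound to a double-bonded ring carbon is not silent in this assay, as the earlier compounds within the scatter had suggested: the series now shows an 18-fold lower number from compound 3 to compound 4 (1.26 log units; beyond the scatter), and fluoro in place of chloro on an aromatic carbon gives a 20-fold lower number from compound 1 to compound 4 (1.30 log units; beyond the scatter). Fluoro in place of methoxy gives only a floor, since one side of that pair is a limit, and it is already large: an at least 20-fold lower number from compound 2 to compound 4 (1.30 log units; beyond the scatter). No measured property in the notes bears on these steps.

As far as these compounds go, the 4-fluorophenyl stands alone at this level, so it remains open whether the step is specific to fluoro. An unsubstituted phenyl, a trifluoromethyl or an amine on this phenyl would help to settle that.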